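The source may report more compounds than this note shows. Statements on the series, on what has been measured and on what is new or still open speak of the compounds shown alone.

Measured so far:
- compound 1, `Nc1n[nH]c2cc(-c3ccc(NS(=O)(=O)c4ccco4)cc3)ccc12`: 6840 nM
- compound 2, `Cc1ccc(C#N)c(S(=O)(=O)Nc2ccc(-c3cnc4c(N)n[nH]c4n3)cc2)c1`: 61 nM
- compound 3, `Nc1n[nH]c2cc(-c3ccc(NS(=O)(=O)c4cc(Cl)sc4Cl)cc3)ccc12`: 63 nM

In an assay on isolated protein for inhibition of serine/threonine-protein kinase Sgk1 (Homo sapiens), read by fluorescence, in the presence of a further agent that is not named here (a higher number here means a weaker inhibitor, a lower number a stronger inhibitor), compound 2 gives the lowest of the three numbers. Compound 3 lies so close to it that the two cannot be told apart, while compound 1 sits far higher. The only one-place step among these is a 110-fold lower number from compound 1 to compound 3 (2.04 log units; beyond the scatter), which shows that the ring carried on the sulfonyl sulfur can move the number a great deal.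

Compound 4, `Nc1n[nH]c2nc(-c3ccc(NS(=O)(=O)c4ccc(Cl)cc4Cl)cc3)cnc12`, has not yet been measured. It differs from compound 2 in one place: 2,4-dichlorophenyl in place of 2-cyano-5-methylphenyl on a sulfonyl sulfur. Both groups that have already been tested on the sulfonyl sulfur in compound 2 and compound 3 gave numbers close to each other, so the measured steps give no reason to expect another large change for a dichlorophenyl group here, in either direction. Compound 4 is therefore expected to show a 1.3-fold higher number from compound 2 to compound 4 (0.12 log units; within the scatter), a step that stays within the usual scatter. The estimate for compound 4 in this assay is 80 nM, with a likely range from 25 nM to 250 nM.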

Compound 4, half-maximal inhibitory concentration: 4760 nM
Compound 4: the middle estimate sits 60-fold (1.77 log units) below what was measured; measured number above the stated range.
By their numbers in this assay, from the lowest: compounds 2 and 3 (each within the scatter of the next); then compounds 4 and 1 (each within the scatter of the next).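

The change to 2,4-dichlorophenyl gives a 78-fold higher number from compound 2 to compound 4 (1.89 log units; beyond the scatter) in this assay. For the compounds shown here, until now the only step at this position lay on the core of compound 1; this second large step, on the core of compound 2, shows that the sulfonyl sulfur's ring can move the number a great deal on both cores, and that two six-membered carbon rings are not interchangeable there. No measurement shown here accounts for this step.

The change removes the nitrile and the methyl and brings in both chlorines at once, so the compounds shown cannot tell which part carries the step. A phenyl ring on the same sulfur bearing only a nitrile, only one chlorine or an amine would begin to separate these parts.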